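Removing a Methyl from a Weak Hydantoin Series

This account rests on a few compounds, and the source may have more. Where it says the series, first, only, none or still open, it means among the compounds named here.

Measured so far:
- compound 1, `CCC(C)C1NC(=O)N(C2CCCCC2)C1=O`: 94300 nM
- compound 2, `CCC(C)C1NC(=O)N(C2CCCC2)C1=O`: 67400 nM
- compound 3, `CC(C)C1NC(=O)N(C2CCCC2)C1=O`: > 100000 nM

All three compounds were tested in a functional assay on MCF7 cells (Homo sapiens) for inhibition; a lower number here means a stronger inhibitor, a higher number a weaker inhibitor. Compound 1 gives 94300 nM and compound 2 gives 67400 nM; the two numbers lie within the usual scatter of each other, so neither can be called the stronger. The difference between the cores of compound 1 and compound 2 is not broken down here. For compound 3 the result is only a limit of the assay, > 100000 nM, not a number; this is the limit of > 100000 nM in this assay, at which 1 of the 3 values shown sits.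

Compound 3 arises from compound 2 by one change, (hydrogen in place of methyl on a saturated chain carbon, two bonds along the chain from a saturated ring carbon). The step is an at least 1.4-fold higher number from compound 2 to compound 3 (0.17 log units; that floor lies within the scatter), meaning the inhibition became weaker or at best stayed the same.

The same change applied to compound 1 gives compound 4, `CC(C)C1NC(=O)N(C2CCCCC2)C1=O`, which has not yet been measured: hydrogen in place of methyl on a saturated chain carbon, two bonds along the chain from a saturated ring carbon. Because compound 1 already sits at 94300 nM, and because the step of an at least 1.4-fold higher number from compound 2 to compound 3 (0.17 log units; that floor lies within the scatter) went toward weaker inhibition, compound 4 is expected to be no stronger than compound 1 and probably weaker. The expected step is a 1.6-fold higher number from compound 1 to compound 4 (0.20 log units; within the scatter). In this assay compound 4 is estimated at 150000 nM, with a likely range from 80000 nM to 400000 nM.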

Compound 4, half-maximal inhibitory concentration: > 100000 nM
Compound 4 was reported as a limit; the forecaster's own chance of this, stated with the estimate: 70%; the middle value lies beyond the limit too.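

Replacing the methyl with hydrogen on the core of compound 1, which turns sec-butyl into isopropyl, gives the step of an at least 1.0-fold higher number from compound 1 to compound 4 (0.02 log units; that floor lies within the scatter), and on neither core does the change yield a number that can be read as a stronger inhibitor: the same change on two cores in this assay, an at least 1.4-fold higher number (0.17 log units; that floor lies within the scatter) from compound 2 to compound 3 and an at least 1.0-fold higher number (0.02 log units; that floor lies within the scatter) from compound 1 to compound 4; the limit leaves it open whether they differ

Both products of the change, compound 3 and compound 4, are reported only as limits of the assay rather than as numbers, so the series offers little room to follow this change: the limit of > 100000 nM in this assay, at which 2 of the 4 values shown sit.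

The result therefore shows that the loss of this methyl gave no measurable gain on either core, but it does not show how large the change is on either core, whether it is the same on both, or that it truly weakens inhibition, since both floors lie within the scatter.

The compounds shown leave open whether a longer chain in place of sec-butyl, or an amine or a carboxylic acid on that chain, would give a number clearly lower than the one for compound 2, 67400 nM. They also leave open how this same methyl-to-hydrogen change would read on a core where both partners give true numbers rather than limits.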